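A thiazole in place of a methylpyrazole on the shared core

The source may report more compounds than this note shows. Statements on the series, on what has been measured and on what is new or still open speak of the compounds shown alone.

In a functional assay on CHO cells for agonist activity at Alpha-1A adrenergic receptor (Homo sapiens), read by FLIPR and calcium flux (on this read-out lower numbers stand for an effect already at smaller amounts and higher numbers for an effect only at larger amounts of compound), compound 1 `Cn1ccc(-c2cccc3c2CCC3c2ncc[nH]2)n1` is known only by a limit, > 1300 nM. Compound 2 `Cc1c(OCC2=NCCN2)ccc(Cl)c1NS(C)(=O)=O` gives 25 nM in this assay, and compound 3 `c1ccc2c(c1)CCCC2c1ncc[nH]1` gives 385 nM. Among the numbers shown, compound 1 therefore stands at the limit of > 1300 nM in this assay, at which 1 of the 3 values shown sits, the weak end of what was measured. Among the measured compounds shown here, no step between measured compounds that differ in a single place is available, so nothing measured tells how far a change on the six-membered aromatic ring of the core of compound 1 moves this read-out. Compound 4 `c1cc(-c2nccs2)c2c(c1)C(c1ncc[nH]1)CC2` differs from compound 1 in one place: 1,3-thiazol-2-yl in place of 1-methyl-1H-pyrazol-3-yl on an aromatic carbon. For the measured compounds named here, with no measured step to lean on, only a modest move is expected, and the direction is open. Compound 4 is estimated at 1000 nM, with a range from 200 nM to 5000 nM. That estimate means a step of an at least 1.3-fold lower number from compound 1 to compound 4 (0.11 log units; that floor lies within the scatter) in this assay, expected to stay small against the usual scatter, with a fair chance that compound 4 is again reported only as a limit.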

Compound 4, half-maximal effective concentration: 426 nM
Beside the measured number, compound 4's estimate is 2.3-fold (0.37 log units) above it; low and high end bracket the measured number.
By their numbers in this assay, from the lowest: compound 2; then compounds 3 and 4 (each within the scatter of the next). At a limit, above all of these: compound 1.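

Placing 1,3-thiazol-2-yl instead of 1-methyl-1H-pyrazol-3-yl on this aromatic carbon gives an at least 3.0-fold lower number from compound 1 to compound 4 (0.48 log units; beyond the scatter) in this assay, the first step that can be read at this position. The two groups match in the counts of hetero atoms, hydrogen-bond donors and hydrogen-bond acceptors, and each is a five-membered aromatic ring, yet the exchange still moves the read-out beyond the scatter, so this position does respond to a change between such rings. The step gives only a floor for the size of the change, as compound 1 is known only by a limit: the limit of > 1300 nM in this assay, at which 1 of the 4 values shown sits.

The compounds shown leave open whether the sulfur atom or the loss of the methyl group carries the step. They also leave open how a phenyl ring, an amine or a carboxylic acid on the same aromatic carbon would read in this assay.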